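The compounds below may be only part of what the source reports. "The series", "measured", "known", "first", "only" and "open" are said of these compounds alone.

In a functional assay on Jurkat cells (Homo sapiens) for cytotoxicity, with a stated time of 72 h (a higher number here means that more compound is needed for the effect, a lower number that less compound is needed), compound 1 `C=C[C@](C)(CCCC(C)C)CCc1ccc(O)cc1` reads > 49000 nM as a limit, not a number. Compound 2 `C=C[C@@](C)(/C=C/c1ccc(O)cc1)CC/C=C(C)/C=C/C(=O)OCc1ccccc1` reads > 49000 nM as a limit too. Compound 3 `C=C[C@@](C)(/C=C/c1ccc(O)c(/C=C/C(=O)OCc2ccccc2)c1)CCC=C(C)C` also reads > 49000 nM as a limit, so it stands with no number of its own. The whole picture so far is the limit of > 49000 nM in this assay, at which 3 of the 3 values shown sit, and nothing more. Within the data shown here, compound 4 `C=C[C@@](C)(/C=C/c1ccc(O)c(/C=C/c2ccc(Cl)cc2)c1)CCC=C(C)C` carries 4-chlorophenyl in place of benzyloxycarbonyl on a double-bonded chain carbon bound to a double-bonded chain carbon as its one change. A small move toward less compound needed is expected, perhaps none beyond the scatter, with the estimated step of an at least 1.4-fold lower number from compound 3 to compound 4 (0.14 log units; that floor lies within the scatter) as a rough guide. For compound 4 the estimate is 35000 nM with an expected range from 12000 nM to 60000 nM in this read-out.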

Compound 4, half-maximal effective concentration: > 49000 nM
Compound 4 ended at the assay's limit; the forecaster's own chance of this, stated with the estimate: 60%; middle value at least 1.4-fold (0.14 log units) from the limit.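

Compound 3 and compound 4 both end at a limit rather than a number, so no step can be read between them: the limit of > 49000 nM in this assay, at which 4 of the 4 values shown sit. The compounds shown leave open how much of any of them is needed for the effect in this assay and whether any structural change alters it.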